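The source may report more compounds than this note shows. Statements on the series, on what has been measured and on what is new or still open speak of the compounds shown alone.

Compound 1 `CS(=O)(=O)Cc1nc2c(Sc3ccc(Cl)cc3)cc(Cl)cn2c1[N+](=O)[O-]`: > 31200 nM (a limit)
Compound 2 `Cc1nc2c(Sc3ccc(Cl)cc3)cc(Cl)cn2c1[N+](=O)[O-]`: > 7800 nM (a limit)
Compound 3 `CS(=O)(=O)Cc1nc2c(Br)cc(Cl)cn2c1[N+](=O)[O-]`: 45000 nM

All three were measured in an ADME assay on HepG2 cells (Homo sapiens) for cytotoxicity, read by MTT assay, with a stated time of 72 h (a lower number here means that less compound is tolerated, a higher number that more compound is tolerated), and only compound 3 carries a number. Compound 2 stands at a limit, > 7800 nM, and has no number of its own.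

Compound 4 `O=[N+]([O-])c1c(CSc2ccccc2)nc2c(Sc3ccc(Cl)cc3)cc(Cl)cn12` differs from compound 2 in one place: phenylsulfanyl in place of hydrogen on a saturated chain carbon bound to an aromatic carbon. The measured step at this same chain carbon is a step that the two limits leave unreadable from compound 1 to compound 2. The other measured step, a step that the limit leaves unreadable from compound 1 to compound 3, concerns a change on an aromatic carbon instead. Neither step has a readable size, so neither supplies a direction or a magnitude for compound 4. No step beyond the scatter is therefore expected in this assay, and another limit would not be surprising. The estimate starts from the limit of > 7800 nM in this assay, at which 1 of the 3 values shown sits.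

The expected change is small: a step that the limit leaves unreadable from compound 2 to compound 4. For compound 4 the estimated value is 12000 nM, with an expected range from 4000 nM to 40000 nM.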

Compound 4, half-maximal cytotoxic concentration: > 15600 nM
Compound 4 ended at the assay's limit; the forecaster's own chance of this, stated with the estimate: 60%; middle value at least 1.3-fold (0.11 log units) from the limit.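

In this assay compound 4 gives > 15600 nM, a limit. Its steps from compound 1 and compound 2, which also stand at limits, cannot be read. On these data alone, the size and direction of any change on the saturated chain carbon bound to an aromatic carbon remain open.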